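The source may hold more compounds than are shown below. What is called first, only, known or untested is meant among the compounds shown, and "the series" means these compounds.

Series notes. Within the data shown here, only two compounds carry results in a functional assay on MCF7 cells (Homo sapiens) for cytotoxicity, read by MTT assay, with a stated time of 48 h; on this read-out higher numbers stand for weaker inhibition and lower numbers for stronger inhibition. Compound 1 `C=CC(=C)CC[C@@H]1[C@@]2(C)CCC[C@](C)(COC(=O)/C=C/c3ccc(O)cc3)[C@@H]2CC[C@@]1(C)O` is the one that gives an actual number: in this assay compound 1 gives 16600 nM. Compound 2 `C=C/C(C)=C/C[C@H]1C(=C)CC[C@@H]2[C@]1(C)CCC[C@]2(C)C=O` returns only a limit of the assay, not a number: in this assay compound 2 gives > 40000 nM. Among the measured compounds shown here, the set therefore rests on a single number beside a single limit (the limit of > 40000 nM in this assay, at which 1 of the 2 values shown sits), and no step between two measured compounds that differ in one place is available; nothing in the data ties the core of compound 2 to the core of compound 1.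

Compound 3 `C=CC(=C)CC[C@@H]1[C@@]2(C)CCC[C@](C)(COC(=O)/C=C\c3ccc(O)c(OC)c3)[C@@H]2CC[C@@]1(C)O` keeps the core of compound 1 and differs in one place: 2-(4-hydroxy-3-methoxyphenyl)ethenyl in place of 2-(4-hydroxyphenyl)ethenyl on a carbonyl carbon. For the measured compounds named here, no measured precedent in the set fixes the size of such a change. The step from compound 1 to compound 3 is expected to be small, within the usual scatter, with no direction claimed a 1.1-fold lower number from compound 1 to compound 3 (0.04 log units; within the scatter). Compound 3 is accordingly estimated in this assay at 15000 nM. The estimated range for compound 3 runs from 6000 nM to 40000 nM. Given that upper end, a reading that comes back as a limit rather than a number is also possible.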

Compound 3, half-maximal inhibitory concentration: 15400 nM
Compound 3: middle estimate off by 1.0-fold (0.01 log units), on the low side; the measured number falls inside the stated range.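

This step gives the series its first measured precedent at this position: on the shared core, 2-(4-hydroxy-3-methoxyphenyl)ethenyl in place of 2-(4-hydroxyphenyl)ethenyl on a carbonyl carbon leaves the two numbers in this assay within the scatter of each other (a 1.1-fold lower number from compound 1 to compound 3 (0.03 log units; within the scatter)). The position therefore accepts the larger group, with its added oxygen and added hydrogen-bond acceptor, without a readable difference in this read-out. The ethenyl double bond is also drawn with opposite geometry in compound 1 and compound 3, so the step covers both differences together, and nothing measured here gives a cause for the outcome or bears on it.

From the compounds shown here alone, whether a carboxylic acid or an amine on the aromatic ring, or an amide in place of the ester, would move the number beyond the scatter remains open, as does the effect of each double-bond geometry with the same aryl group. In this assay, among these compounds, compound 2 still gives only a limit (> 40000 nM) and no step ties its core to the shared core of compound 1.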